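Tert-butyl in place of phenyl on the shared core

A few compounds are considered here, and "the series" means these few. Any claim that something is new, unique, unknown or untested is made for them only; others in the source may bear on it.

Within the data shown here, in a functional assay on MDA-MB-231 cells (Homo sapiens) for inhibition, read by sulforhodamine B assay, with a stated time of 48 h (a higher number here means a weaker inhibitor of growth, a lower number a stronger inhibitor of growth), compound 1 `Cc1ccn2c(CN3CCCCC3)c(-c3ccccc3)nc2n1` gives 30 nM and stands lowest of the two numbers so far. Compound 2 `c1ccc(-c2nc3ncccn3c2CN2CCCC2)cc1` gives 70 nM as the nearest number, a gap beyond the usual scatter. The next compound to read is compound 3 `Cc1ccn2c(CN3CCCCC3)c(C(C)(C)C)nc2n1` with tert-butyl in place of phenyl on an aromatic carbon next to the ring atom that bears a (piperidin-1-yl)methyl group. Among the measured compounds shown here, no measured pair shows this change, so the expectation is loose. Compound 1 at 30 nM sits low enough to leave much room for a rise. In this assay a weaker inhibitor of growth is expected, with an estimated step of a 20-fold higher number from compound 1 to compound 3 (1.30 log units; beyond the scatter) beyond the scatter. For compound 3 the expected value is 600 nM within an estimated range of 80 nM to 5000 nM on present evidence.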

Compound 3, concentration for 50% growth inhibition: 350 nM
The estimate for compound 3 lay 1.7-fold (0.23 log units) above the measured number; measured number inside the range.
By their numbers in this assay, from the lowest: compound 1; then compound 2; then compound 3.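

In this assay, among these compounds, this is the first measured change on the aromatic carbon next to the ring atom that bears a (piperidin-1-yl)methyl group, and tert-butyl in place of phenyl gives a 12-fold higher number from compound 1 to compound 3 (1.07 log units; beyond the scatter). The position is therefore not indifferent to this exchange: among the compounds with the (piperidin-1-yl)methyl group, the phenyl of compound 1 goes with the lower number. Even so, compound 3 retains growth inhibition, at 350 nM. No measured evidence is available to explain the size of this step.

From the compounds shown here alone, whether a cyclohexyl ring, a pyridyl ring or a smaller methyl group at this place would stay close to compound 1 remains open. Compound 2 differs from compound 1 in more than one place, so it leaves open whether the step carries over to other amine side chains.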